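A few compounds are considered here, and "the series" means these few. Any claim that something is new, unique, unknown or untested is made for them only; others in the source may bear on it.

Measured so far:
Compound 1, `Cc1cc2[nH]nc(N)c2c(N2CCCCC2)n1`: 10%
Compound 2, `Cc1cc2nn(-c3ccccc3)c(N)c2c(=O)[nH]1`: 5%

Both numbers come from an assay on isolated protein for inhibition of MAP kinase-activated protein kinase 5 (Homo sapiens), read by mobility shift assay, tested at 30 uM; a higher number here means more inhibition at the concentration tested (going by the name of the read-out), a lower number less inhibition. Compound 2, with structure `Cc1cc2nn(-c3ccccc3)c(N)c2c(=O)[nH]1`, gives 5% in this assay, and compound 1 gives 10% there; the two values lie within the usual scatter of each other, so nothing separates them. Both are small readings at the tested concentration.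

The next compound, compound 3, has the structure `COc1ccc(-c2cc3nn(-c4ccccc4)c(N)c3c(=O)[nH]2)cc1`. It differs from compound 2 by the change (4-methoxyphenyl in place of methyl on an aromatic carbon). Within the data shown here, no pair of measured compounds shows a step of this kind, so the size of the step in this assay has no precedent here. Since compound 2 gives only 5%, a small number with little room below it, the step from compound 2 to compound 3 is expected to be a number 4 percentage points higher from compound 2 to compound 3 (within the scatter), which stays within the scatter or only slightly beyond it. Compound 3 is accordingly expected to give about 9% in this assay, within a range from 0% to 28%.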

Compound 3, a percentage reported as inhibition, at one concentration (the size of the read-out at that concentration, not a potency): 12%
Beside the measured number, compound 3's estimate is 3 percentage points below it, and the stated range covers the measured number.
By their numbers in this assay, from the lowest: compounds 2, 1 and 3 (each within the scatter of the next).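

In this assay, putting 4-methoxyphenyl in place of methyl on the aromatic carbon next to the ring nitrogen gives a number 7 percentage points higher from compound 2 to compound 3 (within the scatter), so this first change at the position, which brings in a six-membered aromatic ring and a far larger group, shifts the reading by no more than the usual scatter. With compound 2 already reading so low, a loss of inhibition would scarcely show, so the step says little about whether the position can bear such a group without cost. Nothing measured bears on why the reading stays where it does.

The compounds shown leave open whether plain phenyl, an amine, a carboxylic acid or a longer chain at this position would move the reading beyond the scatter. They also leave open whether the methoxy group on the new ring has any part in the reading.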